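Compound 4: Dihydroxyphenyl in Place of a Halogenated Ring

A few compounds are considered here, and "the series" means these few. Any claim that something is new, unique, unknown or untested is made for them only; others in the source may bear on it.

In a functional assay on HepG2 cells (Homo sapiens) for cytotoxicity, read by MTT assay, with a stated time of 72 h (a higher number here means a weaker inhibitor, a lower number a stronger inhibitor), compound 1 `O=C(N/N=C/c1ccc([N+](=O)[O-])cc1)Nc1cc2c(Nc3ccc(F)c(Cl)c3)ncnc2cc1O[C@H]1CCOC1` gives 35300 nM, compound 2 `O=C(N/N=C/c1ccc(F)cc1Cl)Nc1cc2c(Nc3ccc(F)c(Cl)c3)ncnc2cc1O[C@H]1CCOC1` gives 26100 nM and compound 3 `O=C(N/N=C/c1cc(Br)c(O)c(Br)c1)Nc1cc2c(Nc3ccc(F)c(Cl)c3)ncnc2cc1O[C@H]1CCOC1` gives 2740 nM. Compound 2 thus sits level with compound 1, with a 1.4-fold lower number from compound 1 to compound 2 (0.13 log units; within the scatter), while a 9.5-fold lower number from compound 2 to compound 3 (0.98 log units; beyond the scatter) sets it clearly apart from compound 3. Compound 4 `O=C(N/N=C/c1ccc(O)cc1O)Nc1cc2c(Nc3ccc(F)c(Cl)c3)ncnc2cc1O[C@H]1CCOC1` changes the group on a carbon with a double bond to nitrogen: 2,4-dihydroxyphenyl in place of 2-chloro-4-fluorophenyl on a carbon with a double bond to nitrogen. Within the data shown here, compound 3 is the only measured compound with a hydroxy-bearing ring, but that ring also carries bromine, so its step is only a loose guide. In this assay the expected change is smaller and in the same direction, a 2.6-fold lower number from compound 2 to compound 4 (0.42 log units; beyond the scatter). Compound 4 is estimated at 10000 nM, with an expected range of 3000 nM to 30000 nM.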

Compound 4, half-maximal inhibitory concentration: 4530 nM
Compound 4: the middle estimate sits 2.2-fold (0.34 log units) above what was measured; low and high end bracket the measured number.
By their numbers in this assay, from the lowest: compounds 3 and 4 (each within the scatter of the next); then compounds 2 and 1 (each within the scatter of the next).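

In this assay, a ring bearing hydroxy groups and no halogen stands level with the brominated phenol (a 1.7-fold higher number from compound 3 to compound 4 (0.22 log units; within the scatter)), so among these compounds bromine is not needed for the lower numbers at this position. The dihydroxy ring also separates clearly from the halogenated ring (a 5.8-fold lower number from compound 2 to compound 4 (0.76 log units; beyond the scatter)) and from the nitro-bearing ring (a 7.8-fold lower number from compound 1 to compound 4 (0.89 log units; beyond the scatter)). No measurement shown accounts for these steps.

As far as these compounds go, it remains open whether one hydroxy group alone would suffice, and which of the two carries the change. From the compounds shown here alone, how an amine or a carboxylic acid on this ring would compare also stays unknown.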